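Chain length and liver cell toxicity in a lactone series

The compounds below may be only part of what the source reports. "The series", "measured", "known", "first", "only" and "open" are said of these compounds alone.

Compound 1 `CCCCCCCCC[C@@H]1CC(O)=C(C(=O)CCC)C(=O)O1`: 33 ug/mL
Compound 2 `CCCCCCCCCCC[C@@H]1CC(O)=C(C(=O)CCC)C(=O)O1`: 19 ug/mL
Compound 3 `CCCCCCCCC[C@@H]1CC(O)=C(C(=O)CC)C(=O)O1`: 50 ug/mL

Of the compounds shown here, three sharing one core have been measured in an ADME assay on HepG2 cells (Homo sapiens) for cytotoxicity, read by XTT assay, with a stated time of 48 h; on this read-out higher numbers stand for lower toxicity in this test and lower numbers for higher toxicity in this test. In this assay compound 1 gives 33 ug/mL, compound 2 gives 19 ug/mL, and compound 3 gives 50 ug/mL. Compound 2 differs from compound 1 by ethyl in place of hydrogen on a saturated chain carbon, nine bonds along the chain from a saturated ring carbon, and the step in this assay is a 1.7-fold lower number from compound 1 to compound 2 (0.24 log units; within the scatter). Compound 3 differs from compound 1 by hydrogen in place of methyl on a saturated chain carbon, two bonds along the chain from a carbonyl carbon, a step of a 1.5-fold higher number from compound 1 to compound 3 (0.18 log units; within the scatter). Compound 3 holds the highest number of the three, yet its gap to compound 1 lies within the scatter, so no order between those two can be claimed; only its gap to compound 2 lies beyond the scatter.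

Compound 4 `CCCCCCCCC[C@@H]1CC(O)=C(C(=O)CCCC)C(=O)O1` has not yet been measured. It differs from compound 3 by ethyl in place of hydrogen on a saturated chain carbon, two bonds along the chain from a carbonyl carbon. Within the data shown here, this is the same kind of change as the one from compound 1 to compound 2, but not the same: there the ethyl entered on a saturated chain carbon nine bonds along the chain from a saturated ring carbon, whereas here it enters on a saturated chain carbon two bonds along the chain from a carbonyl carbon. The core of compound 3 differs from the core of compound 1 by hydrogen in place of methyl on a saturated chain carbon, two bonds along the chain from a carbonyl carbon.

Among the measured compounds shown here, the only precedent for adding an ethyl, the step of a 1.7-fold lower number from compound 1 to compound 2 (0.24 log units; within the scatter), was small and within the scatter. For compound 4 the estimated step in this assay is a 1.9-fold lower number from compound 3 to compound 4 (0.28 log units; within the scatter), resting on that precedent and on compound 3 giving 50 ug/mL. Compound 4 is therefore expected to give about 26 ug/mL, with a range from 12 ug/mL to 50 ug/mL.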

Compound 4, half-maximal cytotoxic concentration: 36 ug/mL
Compound 4: the middle estimate sits 1.4-fold (0.14 log units) below what was measured; the range from low to high includes it.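

In this assay, ethyl in place of hydrogen on a saturated chain carbon, two bonds along the chain from a carbonyl carbon, gives a 1.4-fold lower number from compound 3 to compound 4 (0.14 log units; within the scatter), and set beside the earlier ethyl step it shows no difference that can be told apart: the same change on two cores in this assay, a 1.7-fold lower number (0.24 log units; within the scatter) from compound 1 to compound 2 and a 1.4-fold lower number (0.14 log units; within the scatter) from compound 3 to compound 4, 1.3-fold (0.10 log units) apart, within the scatter of two such steps The change therefore carries from one core to the other without a detectable shift in its size, but each step lies within the scatter on its own, so the pair does not show that the change moves the number at all, and two cores, with the ethyl entering at a different place on each, make no rule for the series. The shorter change gives a 1.1-fold higher number from compound 1 to compound 4 (0.04 log units; within the scatter), which is also within the scatter and so sets no order between those two compounds.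

Going by these compounds, all four compounds carry only plain saturated chains on the shared core, so the effect in this assay of an amine or a carboxylic acid on either chain remains open. Also open, on these data alone, is whether a longer chain at either place would carry the step beyond the scatter.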